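Swapping dimethylamino for hydroxy in a growth inhibitor

The source may report more compounds than this note shows. Statements on the series, on what has been measured and on what is new or still open speak of the compounds shown alone.

Measured in a functional assay on DU-145 cells (Homo sapiens) for inhibition, read by trypan blue exclusion, with a stated time of 96 h; a lower number here means a stronger inhibitor of growth, a higher number a weaker inhibitor of growth:
- Compound 1 `O=C(/C(=C\c1ccc(Cl)cc1)SCc1ccc(F)cc1)c1ccc(Cl)cc1`: 10000 nM
- Compound 2 `CN(C)c1ccc(/C=C(/SCc2ccc(F)cc2)C(=O)c2ccc(Cl)cc2)cc1`: 50000 nM

Not yet measured:
- Compound 3 `O=C(/C(=C\c1ccc(O)cc1)SCc1ccc(F)cc1)c1ccc(Cl)cc1`

Of the two measured compounds, compound 2 has the higher number, 50000 nM, which makes it the weaker inhibitor of growth. Compound 3 keeps the same core but has hydroxy in place of dimethylamino on an aromatic carbon. Within the data shown here, only one measured step bears on this change: a 5.0-fold higher number from compound 1 to compound 2 (0.70 log units; beyond the scatter). That modest step, beyond the scatter, also involved dimethylamino on an aromatic carbon, and the compound without that group gave the lower number. Among the measured compounds shown here, no measured compound carries hydroxy, so this guide is weak. A similar or somewhat smaller move towards a lower number in this assay is expected, and the expected step is a 2.5-fold lower number from compound 2 to compound 3 (0.40 log units; beyond the scatter). For compound 3 the estimated value is 20000 nM, with an expected range of 6000 nM to 60000 nM.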

Compound 3, concentration for 50% growth inhibition: 25000 nM
For compound 3 the middle estimate is 1.3-fold (0.10 log units) below the measured one, within the range that was stated.
By their numbers in this assay, from the lowest: compound 1; then compounds 3 and 2 (each within the scatter of the next).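

Replacing dimethylamino with hydroxy, on an aromatic carbon para to a large group, gives a 2.0-fold lower number from compound 2 to compound 3 (0.30 log units; within the scatter) in this assay, so this change does not separate the two groups in this measurement. Chloro at that position does stand apart from hydroxy, with a 2.5-fold higher number from compound 1 to compound 3 (0.40 log units; beyond the scatter), so among these three compounds both replacements of chloro give a higher number, and no compound shown goes against this. No measurement available here accounts for that difference.

Going by these compounds, it remains open whether any other group at this position could match or improve on chloro, such as fluoro, bromo, methoxy or a carboxylic acid. The compounds shown also leave open whether these differences would hold on a different core or in a different assay.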